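The source may hold more compounds than are shown below. What is called first, only, known or untested is meant among the compounds shown, and "the series" means these compounds.

Measured compounds:
- compound 1 `Cc1cccc(NC(=O)c2nn(C)c(-c3ccc(F)cc3)c2C)n1` gives 1.1 nM in a functional assay on HEK293 cells for negative allosteric modulation of metabotropic glutamate receptor 5 (Homo sapiens), read by FLIPR and calcium flux; a lower number here means a stronger inhibitor, a higher number a weaker inhibitor
- compound 2 `Cc1cccc(NC(=O)c2nn(C)c(-c3ccc(F)cc3F)c2C)n1` gives 3.7 nM in this assay
- compound 3 `Cc1cccc(NC(=O)c2nn(C)c(-c3cc(F)cc(F)c3)c2C)n1` gives 5.3 nM in this assay

Among these three, compound 3 carries the highest number. Its distance from compound 2 is small (a 1.4-fold higher number from compound 2 to compound 3 (0.16 log units; within the scatter)), so the two cannot be ranked against each other, while its distance from compound 1 is real (a 4.8-fold higher number from compound 1 to compound 3 (0.68 log units; beyond the scatter)).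

Compound 4 `Cc1cccc(NC(=O)c2nn(C)c(OCC3CCCCC3)c2C)n1` has not yet been measured. It differs from compound 3 in one place: cyclohexylmethoxy in place of 3,5-difluorophenyl on an aromatic carbon. Among the measured compounds shown here, every measured step so far moved fluorine atoms around within a phenyl ring (a 3.4-fold higher number from compound 1 to compound 2 (0.53 log units; beyond the scatter), a 4.8-fold higher number from compound 1 to compound 3 (0.68 log units; beyond the scatter), a 1.4-fold higher number from compound 2 to compound 3 (0.16 log units; within the scatter)), and each of those steps was modest. For the measured compounds named here, none of them swaps an aromatic ring for a cyclohexylmethoxy group, so no measured step bears directly on this change; it is a larger alteration than anything tested, and the outcome is correspondingly uncertain. Since the three measured compounds all hold an aromatic ring at this position and all give low numbers, the expectation is that compound 4 gives a higher number, an estimated step of a 7.5-fold higher number from compound 3 to compound 4 (0.88 log units; beyond the scatter). Compound 4 is therefore expected to give about 40 nM, within a range of 5 nM to 400 nM.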

Compound 4, half-maximal inhibitory concentration: 1300 nM
Compound 4: the middle estimate sits 33-fold (1.51 log units) below what was measured; the measured number lies above the stated range.
By their numbers in this assay, from the lowest: compound 1; then compounds 2 and 3 (each within the scatter of the next); then compound 4.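

This position proves far less forgiving than the fluorine shifts suggested: in this assay, exchanging 3,5-difluorophenyl for cyclohexylmethoxy costs much more potency (a 250-fold higher number from compound 3 to compound 4 (2.39 log units; beyond the scatter)) than any rearrangement of fluorine on the phenyl ring. The loss is just as clear when measured from the other two phenyl compounds (a 350-fold higher number from compound 2 to compound 4 (2.55 log units; beyond the scatter); a 1200-fold higher number from compound 1 to compound 4 (3.07 log units; beyond the scatter)), so it does not depend on which fluorinated phenyl serves as the reference. Size as counted here cannot account for the loss, since the leaving and entering groups each have 8 heavy atoms and one six-membered ring, and nothing available explains why the change matters so much.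

The swap alters two things at once, replacing an aromatic ring with a non-aromatic one and adding an oxygen link to the core, so the compounds shown cannot separate these two changes. A cyclohexyl ring attached directly to the core, or a phenoxy group that keeps the oxygen link together with an aromatic ring, would pull them apart.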